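The source may report more compounds than this note shows. Statements on the series, on what has been measured and on what is new or still open speak of the compounds shown alone.

Compound 1 `Cc1ccc(C(=O)C2=C(O)C(=O)N(CC(C)O)C2c2ccc(C(C)(C)C)cc2)cc1`: 123%
Compound 2 `Cc1ccc(C(=O)C2=C(O)C(=O)N(CC(C)O)C2c2ccc(OC(F)(F)F)cc2)cc1`: 110%
Compound 3 `Cc1ccc(C(=O)C2=C(O)C(=O)N(CC(C)O)C2c2cc(C(F)(F)F)cc(C(F)(F)F)c2)cc1`: 109%

In an assay on isolated protein for inhibition of annexin A2/S100-A10 (Homo sapiens), with a stated time of 5 min, tested at 50 uM (a higher number here means more inhibition at the concentration tested (going by the name of the read-out), a lower number less inhibition), compound 1 stands highest of the three numbers, with compound 2 and compound 3 each falling beyond the scatter below it. Compound 4 `Cc1ccc(C(=O)C2=C(O)C(=O)N(CC(C)O)C2c2cc(Cl)cc(Cl)c2)cc1` differs from compound 1 in a single place: 3,5-dichlorophenyl in place of 4-(tert-butyl)phenyl on a saturated ring carbon. Within the data shown here, the one measured step at that place is a number 13 percentage points lower from compound 1 to compound 2 (beyond the scatter), and compound 3, which carries trifluoromethyl groups at the same place, gives a value close to that of compound 2. Both changes away from tert-butyl lowered the number modestly, so a step of similar size and direction is expected here, about a number 14 percentage points lower from compound 1 to compound 4 (beyond the scatter). Compound 4 is therefore estimated to give 109%, with a range from 96% to 122%.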

Compound 4, a percentage reported as inhibition, at one concentration (the size of the read-out at that concentration, not a potency): 119%
Compound 4: the middle estimate sits 10 percentage points below what was measured, and the stated range covers the measured number.
By their numbers in this assay, from the lowest: compounds 3, 2, 4 and 1 (each within the scatter of the next, the first and the last beyond it).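

In this assay the change to 3,5-dichlorophenyl gives a number 4 percentage points lower from compound 1 to compound 4 (within the scatter) and so the 4-(tert-butyl)phenyl group is not needed to hold the number at this position. Among the steps shown here, this is the one that stays within the scatter, while the step to the trifluoromethoxy compound gives a number 13 percentage points lower from compound 1 to compound 2 (beyond the scatter) as a small but real drop. Nothing measured here explains the difference between these two steps.

As far as these compounds go, it remains open how a phenyl ring carrying a single chlorine would compare. A phenyl ring bearing an amine or a carboxylic acid at this position is also an open case.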